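This account rests on a few compounds, and the source may have more. Where it says the series, first, only, none or still open, it means among the compounds named here.

Compound 1 `COc1cc(CN(CC(N)=O)C(=O)c2cccs2)ccc1OCc1ccc(F)cc1`: 9100 nM
Compound 2 `COC(=O)[C@@H](c1ccccc1)N(Cc1cccc(OC)c1)C(=O)c1ccccc1`: 210 nM

In an assay on HEK293 cells for antagonist activity at transient receptor potential cation channel subfamily M member 8 (Homo sapiens), read by calcium flux (on this read-out lower numbers stand for stronger inhibition and higher numbers for weaker inhibition), compound 1 gives 9100 nM, the higher of the two numbers; compound 2, with 210 nM, sits far lower, a gap beyond the usual scatter. The unmeasured compound 3 `COc1cc(CN(C(=O)c2cccs2)[C@@H](C(N)=O)c2ccccc2)ccc1OCc1ccc(F)cc1` keeps the core of compound 1 and differs in one spot: phenyl in place of hydrogen on a saturated chain carbon bound to an amide-type nitrogen and a carbonyl carbon. For the measured compounds named here, no measured pair here isolates this change, so its size is a guess; still, compound 2, the stronger compound, also carries a phenyl on the chain carbon beside the amide nitrogen, which leans toward a gain. The step from compound 1 to compound 3 in this assay is expected to be a clear drop, a 10-fold lower number from compound 1 to compound 3 (1.00 log units; beyond the scatter). Compound 3 is therefore estimated at about 900 nM, somewhere between 200 nM and 4000 nM.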

Compound 3, half-maximal inhibitory concentration: > 100000 nM
Compound 3: no number, only a limit; the forecaster's own chance of this, stated with the estimate: 5%; middle value at least 110-fold (2.04 log units) from the limit.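

On a saturated chain carbon bound to an amide-type nitrogen and a carbonyl carbon, phenyl in place of hydrogen costs the core of compound 1 much of its inhibition: in this assay the change gives an at least 10-fold higher number from compound 1 to compound 3 (1.04 log units; beyond the scatter). That step is only a minimum, and the true loss may be larger. Compound 3 has no exact number, only a limit of the assay: the limit of > 100000 nM in this assay, at which 1 of the 3 values shown sits.

The compounds shown leave open how a smaller methyl or a benzyl would read on this carbon. They also leave open whether the mirror-image form of compound 3 would read the same.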